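Replacing 4-nitrophenyl with 2-methylbutyl in compound 2

A few compounds are considered here, and "the series" means these few. Any claim that something is new, unique, unknown or untested is made for them only; others in the source may bear on it.

Values measured in a functional assay on NCI-H69 cells (Homo sapiens) for cytotoxicity, read by MTT assay, with a stated time of 3 days (a higher number here means a weaker inhibitor, a lower number a stronger inhibitor), follow
Compound 1 `CCCCCOC(=O)Nc1nc(=O)n([C@@H]2O[C@H](C)[C@H]3OC(=O)O[C@H]32)cc1F` gives 180 ug/mL
Compound 2 `C[C@H]1O[C@@H](n2cc(F)c(NC(=O)Oc3ccc([N+](=O)[O-])cc3)nc2=O)[C@@H]2OC(=O)O[C@@H]21` gives 30 ug/mL
Compound 3 `C[C@H]1O[C@@H](n2cc(F)c(NC(=O)Oc3ccc([N+](=O)[O-])cc3)nc2=O)[C@H](O)[C@@H]1O` gives 100 ug/mL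

Compound 2 holds the lowest of the three numbers, and the other two lie beyond the scatter from it. The unmeasured compound 4 (`CCC(C)COC(=O)Nc1nc(=O)n([C@@H]2O[C@H](C)[C@H]3OC(=O)O[C@H]32)cc1F`) differs from it by 2-methylbutyl in place of 4-nitrophenyl on an oxygen next to a carbonyl group with 2-methylbutyl in place of 4-nitrophenyl on an oxygen next to a carbonyl group. The closest evidence is a 6.0-fold lower number from compound 1 to compound 2 (0.78 log units; beyond the scatter) as pentyl gives way to 4-nitrophenyl, which is here run the other way. The step of a 3.3-fold higher number from compound 2 to compound 3 (0.52 log units; beyond the scatter) concerns the group on an aromatic nitrogen, which stays unchanged here, so it bears little. In this assay the expected step is a 5.7-fold higher number from compound 2 to compound 4 (0.75 log units; beyond the scatter) and thus upward and beyond the scatter. Compound 4 is estimated at 170 ug/mL within an expected range of 80 ug/mL to 350 ug/mL on this reading.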

Compound 4, half-maximal inhibitory concentration: 330 ug/mL
The estimate for compound 4 lay 1.9-fold (0.29 log units) below the measured number; the measured number falls inside the stated range.
By their numbers in this assay, from the lowest: compound 2; then compounds 3, 1 and 4 (each within the scatter of the next, the first and the last beyond it).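

In this assay, the change from 4-nitrophenyl to 2-methylbutyl on this oxygen gives a large step (an 11-fold higher number from compound 2 to compound 4 (1.04 log units; beyond the scatter)), so a second saturated chain stands well apart from 4-nitrophenyl, as pentyl did. The two chains lie within the scatter of each other (a 1.8-fold higher number from compound 1 to compound 4 (0.26 log units; within the scatter)), so pentyl and 2-methylbutyl cannot be told apart here. Nothing measured on these compounds bears on this gap.

The compounds shown leave open whether a plain phenyl or a 4-methoxyphenyl on this oxygen would keep the low number of compound 2, and whether a longer chain would match pentyl.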